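Removing the amide acyl group from the sulfonamide side chain

This account rests on a few compounds, and the source may have more. Where it says the series, first, only, none or still open, it means among the compounds named here.

Compound 1 `CC(C)C(=O)NCCS(=O)(=O)NC(=O)c1ccc(Nc2nc(NC3(c4ccc(Cl)cc4)CC3)nc(OCC(F)(F)F)n2)cc1` carries an isobutyryl amide on the side-chain nitrogen and, in an ADME assay on microsomes from liver (Rattus norvegicus) for metabolic stability, with a stated time of 10 min (a higher number here means that more of the compound is left, a lower number that less of the compound is left), compound 1 gives 84%. Among the compounds with values here, compound 2 `CC(=O)NCCS(=O)(=O)NC(=O)c1ccc(Nc2nc(NC3(c4ccc(Cl)cc4)CC3)nc(OCC(F)(F)F)n2)cc1` carries the acetyl amide instead, and in this assay compound 2 gives 100%; the step of a number 16 percentage points higher from compound 1 to compound 2 (beyond the scatter) is the only measured step. Compound 3 `O=C(NS(=O)(=O)CCNC(=O)C1CC1)c1ccc(Nc2nc(NC3(c4ccc(Cl)cc4)CC3)nc(OCC(F)(F)F)n2)cc1` carries the cyclopropylcarbonyl amide; in this assay compound 3 was recorded as "not active" (no number reported), so no single number for it is known. Compound 4 `NCCS(=O)(=O)NC(=O)c1ccc(Nc2nc(NC3(c4ccc(Cl)cc4)CC3)nc(OCC(F)(F)F)n2)cc1`, not yet measured, differs from compound 3 by hydrogen in place of cyclopropylcarbonyl on an amine nitrogen. Within the data shown here, the one measured step, from isopropyl to methyl on the carbonyl carbon, moved the read-out upward when the acyl group shrank; the change to compound 4 removes the acyl group altogether. Among the measured compounds shown here, with no number for compound 3, no step can be built, and the expectation rests on compounds 1 and 2 alone. Compound 4 is therefore expected to give about 85%, within 60% to 100%.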

Compound 4, percent of the compound remaining: 100%
The estimate for compound 4 lay 15 percentage points below the measured number; measured number inside the range.
By their numbers in this assay, from the lowest: compound 1; then compounds 2 and 4 (each within the scatter of the next).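

In this assay hydrogen in place of acetyl on the amine nitrogen gives no change at the digits printed from compound 2 to compound 4 (within the scatter) and hydrogen in place of isopropylcarbonyl gives a number 16 percentage points higher from compound 1 to compound 4 (beyond the scatter). The acyl group can therefore go entirely without a loss in this read-out, and among the compounds with numbers only the isobutyryl amide of compound 1 stands apart from the others. The step from compound 3 to compound 4 cannot be read, and nothing available explains these results.

Where the cyclopropylcarbonyl amide of compound 3 stands relative to the free amine remains open. Also open, as far as these compounds go, is whether a dimethylamino group, a carboxylic acid or a longer chain in place of the 2-aminoethyl group would give a read-out like that of compound 4.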